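Fluorine on the cyclobutyl amide of compound 3

The compounds below may be only part of what the source reports. "The series", "measured", "known", "first", "only" and "open" are said of these compounds alone.

Compound 1 `CCCCN1CCc2nc(C#Cc3ccccc3)sc2C1` carries a butyl on the amine nitrogen of the shared core. In an assay on HEK293 cells for negative allosteric modulation of metabotropic glutamate receptor 5 (Homo sapiens), read by FLIPR, with a stated time of 1 h (on this read-out lower numbers stand for stronger inhibition and higher numbers for weaker inhibition), compound 1 gives only the limit > 10000 nM. Compound 2 `CC1CC1C(=O)N1CCc2nc(C#Cc3ccccc3)sc2C1` carries a (2-methylcyclopropyl)carbonyl on that nitrogen, and in this assay compound 2 likewise gives only the limit > 10000 nM. Among the compounds with values here, compound 3 `O=C(C1CCC1)N1CCc2nc(C#Cc3ccccc3)sc2C1`, with a cyclobutylcarbonyl there, is the one compound of the three with a number: in this assay compound 3 gives 370 nM. The step of an at least 27-fold lower number from compound 1 to compound 3 (1.43 log units; beyond the scatter) and the step of an at least 27-fold lower number from compound 2 to compound 3 (1.43 log units; beyond the scatter) are both large, their full size hidden by the limit of > 10000 nM in this assay, at which 2 of the 3 values shown sit; the step that the two limits leave unreadable from compound 1 to compound 2 cannot be read for the same reason.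

Compound 4 `O=C(C1CC(F)C1)N1CCc2nc(C#Cc3ccccc3)sc2C1` differs from compound 3 by fluoro in place of hydrogen on a saturated ring carbon, cyclobutyl to 3-fluorocyclobutyl. Within the data shown here, no measured step changes a substituent on the ring of the amide; the measured steps exchange the whole group on the carbonyl or on the nitrogen, so they bear on this change only indirectly, telling that the group on the carbonyl weighs heavily. A single fluoro on a saturated ring carbon is a smaller change than any of them, so in this assay a step not beyond the scatter is expected, in either direction. Compound 4 is estimated at 350 nM, within 120 nM to 1200 nM, meaning the expected step of a 1.1-fold lower number from compound 3 to compound 4 (0.02 log units; within the scatter).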

Compound 4, half-maximal inhibitory concentration: > 10000 nM
Compound 4: no number, only a limit; the forecaster's own chance of this, stated with the estimate: 10%; at least 28-fold (1.45 log units) between middle value and limit.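

Within the data shown here, this is the first step that changes the ring of the amide rather than exchanging the whole group: in this assay, fluoro in place of hydrogen on a saturated ring carbon, two ring bonds from the ring atom that bears a large group, gives an at least 27-fold higher number from compound 3 to compound 4 (1.43 log units; beyond the scatter). Among these compounds, the earlier steps showed only that the choice of group on the carbonyl or the nitrogen weighs heavily; this one shows that a change of a single atom on the four-membered ring can weigh as heavily, so that the cyclobutylcarbonyl of compound 3 does not tolerate every small substituent at this position. The full size of this step stays hidden and the steps to compound 4 from compound 1 and compound 2 cannot be read, because each involves a limit and not a number: the limit of > 10000 nM in this assay, at which 3 of the 4 values shown sit.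

From the compounds shown here alone, whether a methyl, a hydroxyl or a second fluoro on this ring carbon would also leave only a limit in this assay remains open. Going by these compounds, it is also open whether a number returns with a cyclopentyl on the carbonyl, or whether a fluoro on that larger ring gives the same outcome.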